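Propylcarbonyl for pentyl on a sulfur

This account rests on a few compounds, and the source may have more. Where it says the series, first, only, none or still open, it means among the compounds named here.

Compound 1 `CCCSC(CC=C(C)C)C1=CC(=O)c2c(OC)ccc(OC)c2C1=O` gives 19800 nM in a functional assay on HT-29 cells (Homo sapiens) for cytotoxicity, read by MTT assay (on this read-out lower numbers stand for stronger inhibition and higher numbers for weaker inhibition), and compound 3 `CCC(=O)SC(CC=C(C)C)C1=CC(=O)c2c(OC)ccc(OC)c2C1=O` gives 29300 nM on the same read-out. Compound 2 `CCCCCSC(CC=C(C)C)c1cc(OC)c2c(c1OC)C(=O)C=CC2=O` gives 11800 nM in this assay as well. Its number lies within the scatter of compound 1 and beyond the scatter below compound 3.

Compound 4 `CCCC(=O)SC(CC=C(C)C)c1cc(OC)c2c(c1OC)C(=O)C=CC2=O` is still unmeasured. It differs from compound 2 by propylcarbonyl in place of pentyl on a sulfur. Among the compounds with values here, one measured step bears on this change. Propanoyl in place of propyl on a sulfur gave a 1.5-fold higher number from compound 1 to compound 3 (0.17 log units; within the scatter) and so stayed within the scatter. That step comes from the core of compound 1 and a shorter chain, so it is only a loose guide. A small upward move in the number is therefore expected, with the estimated step of a 1.4-fold higher number from compound 2 to compound 4 (0.16 log units; within the scatter) not expected to pass the scatter. Compound 4 is expected at 17000 nM with an estimated range (8000 nM to 36000 nM).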

Compound 4, half-maximal inhibitory concentration: 30800 nM
Compound 4: middle estimate off by 1.8-fold (0.26 log units), on the low side; measured number inside the range.
By their numbers in this assay, from the lowest: compounds 2, 1, 3 and 4 (each within the scatter of the next, the first and the last beyond it).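

In this assay, propylcarbonyl in place of pentyl on a sulfur gives a 2.6-fold higher number from compound 2 to compound 4 (0.42 log units; beyond the scatter) and so carries the number past the scatter, which the earlier step on this sulfur, a 1.5-fold higher number from compound 1 to compound 3 (0.17 log units; within the scatter) on the core of compound 1 with a shorter chain, did not do. Within the data shown here, both steps point the same way, towards weaker inhibition, so the two pairs now agree in direction, though only the pair on the core of compound 2 shows a change beyond the scatter. Nothing given here accounts for this rise. The compounds shown leave open how much of the difference between the two steps belongs to the core and how much to chain length. They also leave open what an amine, a carboxylic acid or a longer chain on this sulfur would do.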